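Adding a nitro group to compound 2

The source may hold more compounds than are shown below. What is called first, only, known or untested is meant among the compounds shown, and "the series" means these compounds.

Among the compounds with values here, compound 2 `COc1cc2c(cc1O)CCC(C(=O)Nc1ccccc1)O2` gives 6900 nM in a functional assay (brain) for inhibition, with Rattus norvegicus as the target (a lower number here means a stronger inhibitor, a higher number a weaker inhibitor), the lowest number measured so far. Compound 1 `CCCNC(=O)C1CCc2cc(O)c(OC)cc2O1` has propyl where compound 2 has phenyl on the amide nitrogen. Compound 1 gives 119000 nM. Compound 3 `COc1cc2c(cc1O)CCC(C(=O)O)O2`, with hydroxy on the carbonyl carbon, reads > 300000 nM, and this value is only a limit of the assay.

Compound 4 `COc1cc2c(cc1O)CCC(C(=O)Nc1ccc([N+](=O)[O-])cc1)O2` differs from compound 2 by one change, nitro in place of hydrogen on an aromatic carbon, para to a large group. Within the data shown here, two measured steps bear on this only indirectly. Putting phenyl in place of propyl gave a 17-fold lower number from compound 1 to compound 2 (1.24 log units; beyond the scatter), and putting hydroxy in place of anilino gave an at least 43-fold higher number from compound 2 to compound 3 (1.63 log units; beyond the scatter). Both are large, so the group on the carbonyl carbon clearly matters among these compounds, but neither step adds anything to the phenyl ring. Among the measured compounds shown here, no measured compound carries a substituent there, so the data give no direction. In this assay, no change beyond the scatter is therefore expected. The expected step is a 1.2-fold lower number from compound 2 to compound 4 (0.06 log units; within the scatter). For compound 4 the estimated value is 6000 nM, with an expected range of 2000 nM to 20000 nM.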

Compound 4, half-maximal inhibitory concentration: 3800 nM
Compound 4: middle estimate off by 1.6-fold (0.20 log units), on the high side, and the stated range covers the measured number.
By their numbers in this assay, from the lowest: compounds 4 and 2 (each within the scatter of the next); then compound 1. At a limit, above all of these: compound 3.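

Nitro in place of hydrogen gives a 1.8-fold lower number from compound 2 to compound 4 (0.26 log units; within the scatter) in this assay. Within the data shown here, compound 4 is the first compound here with a substituent on this phenyl ring, and it shows that an aromatic carbon para to a large group can carry nitro, with its 3 heavy atoms, without a change that stands out from the scatter of repeated measurements. No information given here bears on why this step is so small.

The compounds shown leave open whether other groups at this same carbon, such as an amine or a carboxylic acid, would also stay within the scatter of compound 2. They also leave open what a group such as chlorine would do on the other carbons of this ring.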